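The source may report more compounds than this note shows. Statements on the series, on what has been measured and on what is new or still open speak of the compounds shown alone.

Compound 1 `COc1ccc(NC(=O)NCCCOc2cccc(CN3CCCCC3)c2)c(OC)c1` is a urea that carries a 2,4-dimethoxyphenyl group on an amide-type nitrogen. Within the data shown here, in an assay on isolated protein for inhibition of histamine H2 receptor (Cavia porcellus) (on this read-out higher numbers stand for weaker binding and lower numbers for tighter binding), compound 1 gives 2240 nM, the highest of the three numbers measured so far. Compound 2 `CCC(C)NC(=O)NCCCOc1cccc(CN2CCCCC2)c1`, with sec-butyl at that place, gives 95.5 nM in this assay, and compound 3 `O=C(NCCCOc1cccc(CN2CCCCC2)c1)Nc1cccc(C(F)(F)F)c1`, with 3-(trifluoromethyl)phenyl there, gives 813 nM. The measured steps are a 23-fold lower number from compound 1 to compound 2 (1.37 log units; beyond the scatter), a 2.8-fold lower number from compound 1 to compound 3 (0.44 log units; beyond the scatter) and an 8.5-fold higher number from compound 2 to compound 3 (0.93 log units; beyond the scatter). Compound 4 `CCCCNC(=O)NCCCOc1cccc(CN2CCCCC2)c1` has not yet been measured in this assay. It differs from compound 1 as follows: butyl in place of 2,4-dimethoxyphenyl on an amide-type nitrogen. The step that bears most directly on this change is the one in which sec-butyl replaced the same 2,4-dimethoxyphenyl group, a large move toward tighter binding, and the change to compound 4 likewise puts a chain with no ring in place of the aromatic group. A step of about a 19-fold lower number from compound 1 to compound 4 (1.27 log units; beyond the scatter) is therefore expected. The estimated value of compound 4 in this assay is 120 nM, with a range from 40 nM to 400 nM.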

Compound 4, dissociation constant: 81.3 nM
Compound 4: the middle estimate sits 1.5-fold (0.17 log units) above what was measured, within the range that was stated.
By their numbers in this assay, from the lowest: compounds 4 and 2 (each within the scatter of the next); then compound 3; then compound 1.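

In this assay, this place on the amide-type nitrogen does not separate butyl from sec-butyl: a 1.2-fold lower number from compound 2 to compound 4 (0.07 log units; within the scatter) means that a second chain with no ring lands at the same level as the first. The drop in the number also now holds against both aromatic groups, with a 28-fold lower number from compound 1 to compound 4 (1.44 log units; beyond the scatter) and a 10-fold lower number from compound 3 to compound 4 (1.00 log units; beyond the scatter), so among these four compounds both ring-free chains stand beyond the scatter from both aryl ureas, and none goes against this. No supporting data bear on what lies behind this difference.

From the compounds shown here alone, it remains open whether a shorter chain such as ethyl or a longer chain such as hexyl would hold this level. Also open, going by these compounds, is where cyclohexyl or unsubstituted phenyl would fall, and so whether the aromatic ring itself or its substituents set the higher numbers of the aryl ureas.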